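Hydroxymethyl for ethoxycarbonyl on the shared pyrazole-bearing series

The source may hold more compounds than are shown below. What is called first, only, known or untested is meant among the compounds shown, and "the series" means these compounds.

In a functional assay on Maver1 cells (Homo sapiens) for inhibition, read by luminescence and CellTiter-Glo, with a stated time of 72 h (on this read-out lower numbers stand for stronger inhibition and higher numbers for weaker inhibition), compound 2 `C=CC(=O)Nc1cccc(Cn2nc(-c3ccc(Oc4ccccc4)cc3)cc2C(=O)OCC)c1` gives 8600 nM, the higher of the two numbers recorded so far, though compound 1 `C/C=C/C(=O)Nc1cccc(Cn2nc(-c3ccc(Oc4ccccc4)cc3)cc2CO)c1` sits within the scatter of it at 8100 nM in this assay. Compound 3 `C=CC(=O)Nc1cccc(Cn2nc(-c3ccc(Oc4ccccc4)cc3)cc2CO)c1` differs from compound 2 by hydroxymethyl in place of ethoxycarbonyl on an aromatic carbon. Going by the values given here, no step between measured compounds isolates this exchange; since compound 1 carries the same hydroxymethyl group and gives 8100 nM, the change is expected to move this assay by no more than the scatter, if anything toward a slightly lower number. For compound 3 the estimated value in this assay is 7000 nM, within 2500 nM to 20000 nM, a step of a 1.2-fold lower number from compound 2 to compound 3 (0.09 log units; within the scatter).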

Compound 3, half-maximal inhibitory concentration: 6700 nM
The estimate for compound 3 lay 1.0-fold (0.02 log units) above the measured number; the range from low to high includes it.
By their numbers in this assay, from the lowest: compounds 3, 1 and 2 (each within the scatter of the next).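

In this assay hydroxymethyl in place of ethoxycarbonyl on the aromatic carbon next to the ring nitrogen gives a small step (a 1.3-fold lower number from compound 2 to compound 3 (0.11 log units; within the scatter)), so this exchange does not separate the two compounds. Vinyl in place of prop-1-en-1-yl on a carbonyl carbon also stays within the scatter (a 1.2-fold lower number from compound 1 to compound 3 (0.08 log units; within the scatter)), so neither place yet shows a clear effect on this read-out. No measurement available here explains why these numbers stay so close. Going by these compounds, whether an amine, a carboxylic acid or a longer chain on this ring carbon would move the number beyond the scatter remains open.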